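Trimethoxyphenyl for methylphenyl in a short enone series

The source may report more compounds than this note shows. Statements on the series, on what has been measured and on what is new or still open speak of the compounds shown alone.

Measured so far:
Compound 1 `COc1cc(C(=O)/C=C/c2cc(-c3cc(OC)c(OC)c(OC)c3)n3nc(-c4ccccc4)cc3n2)cc(OC)c1OC`: 34900 nM
Compound 2 `COc1ccc(-c2cc(C(=O)/C=C/c3ccc(C)cc3)nc3cc(-c4ccccc4)nn23)cc1OC`: 19500 nM
Compound 3 `COc1cc(-c2cc(/C=C/C(=O)c3ccc(C)cc3)nc3cc(-c4ccccc4)nn23)cc(OC)c1OC`: 27100 nM

In a functional assay on DU-145 cells (Homo sapiens) for antiproliferative activity, read by MTT assay, with a stated time of 24 h (on this read-out higher numbers stand for weaker inhibition and lower numbers for stronger inhibition), compound 1 gives 34900 nM, compound 2 gives 19500 nM and compound 3 gives 27100 nM. All three sit within the usual scatter of one another, so no order is claimed. For the measured compounds named here, the one change measured so far is 3,4,5-trimethoxyphenyl in place of 4-methylphenyl on a carbonyl carbon; it made a 1.3-fold higher number from compound 3 to compound 1 (0.11 log units; within the scatter). Compound 4 `COc1ccc(-c2cc(C(=O)/C=C/c3cc(OC)c(OC)c(OC)c3)nc3cc(-c4ccccc4)nn23)cc1OC` is not yet measured and comes from compound 2 by 3,4,5-trimethoxyphenyl in place of 4-methylphenyl on a double-bonded chain carbon bound to a double-bonded chain carbon. The difference between the core of compound 2 and the core of compound 3 is not broken down here. The place also differs: on a carbonyl carbon whose other neighbours are a double-bonded chain carbon in the measured pair, on a double-bonded chain carbon bound to a double-bonded chain carbon in the new one, so this is the same kind of change, not the same change. For compound 4 the expected step in this assay is a 1.2-fold higher number from compound 2 to compound 4 (0.09 log units; within the scatter), resting on the measured pair because a 1.3-fold higher number from compound 3 to compound 1 (0.11 log units; within the scatter) stayed within the scatter. Compound 4 is therefore estimated at 24000 nM, in a range from 10000 nM to 55000 nM.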

Compound 4, half-maximal inhibitory concentration: 14700 nM
The estimate for compound 4 lay 1.6-fold (0.21 log units) above the measured number; low and high end bracket the measured number.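

In this assay, 3,4,5-trimethoxyphenyl in place of 4-methylphenyl on a double-bonded chain carbon bound to a double-bonded chain carbon gives a 1.3-fold lower number from compound 2 to compound 4 (0.12 log units; within the scatter). Set beside the earlier step on the other core, the new step shows no difference that exceeds the scatter: the same change on two cores in this assay, a 1.3-fold higher number (0.11 log units; within the scatter) from compound 3 to compound 1 and a 1.3-fold lower number (0.12 log units; within the scatter) from compound 2 to compound 4, 1.7-fold (0.23 log units) apart, within the scatter of two such steps. This shows that the change stays within the scatter on both cores, but it does not show that an effect of fixed size or direction carries from one core to the other, and the place of the change also differs between the two pairs.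

From the compounds shown here alone, whether an amine or a carboxylic acid in place of these aryl groups would move the number beyond the scatter in this assay remains open.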